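A few compounds are considered here, and "the series" means these few. Any claim that something is new, unique, unknown or untested is made for them only; others in the source may bear on it.

Compound 1 `Oc1cccc2c1CCCC2c1c[nH]cn1` carries a hydroxy group on its core, and in an assay on isolated protein for binding affinity to Alpha-2B adrenergic receptor (Rattus norvegicus), read by radioligand binding (on this read-out higher numbers stand for weaker inhibition and lower numbers for stronger inhibition), compound 1 gives 3.8 nM, the lowest of the two numbers recorded so far. Within the data shown here, the only other measured compound, compound 2 `CCS(=O)(=O)Nc1ccc2c(c1)C(c1c[nH]cn1)CCC2`, bears an ethylsulfonylamino substituent instead, and in this assay compound 2 gives 22.4 nM; the gap between these two values lies beyond the usual scatter, so compound 1 binds the more tightly of the two. Compound 3 `O=C(Nc1cccc2c1CCCC2c1c[nH]cn1)C(F)(F)F` has not yet been measured. It differs from compound 1 by ((trifluoromethyl)carbonyl)amino in place of hydroxy on an aromatic carbon. Among the measured compounds shown here, no measured pair shows this exchange, and compound 2 differs from compound 1 in more than one respect, so no step between measured compounds guides the expectation directly. A step of moderate size toward a higher number is expected, a 3.2-fold higher number from compound 1 to compound 3 (0.50 log units; beyond the scatter). For compound 3 in this assay the estimate is 12 nM, with a range from 3 nM to 50 nM.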

Compound 3, inhibition constant: 661 nM
Beside the measured number, compound 3's estimate is 55-fold (1.74 log units) below it; measured number above the stated range.
By their numbers in this assay, from the lowest: compound 1; then compound 2; then compound 3.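

In this assay the step is a 170-fold higher number from compound 1 to compound 3 (2.24 log units; beyond the scatter) for ((trifluoromethyl)carbonyl)amino in place of hydroxy, which shows that the numbers at this aromatic carbon depend strongly on the group it carries. Hydroxy and the entering group each count one hydrogen-bond donor and one hydrogen-bond acceptor and carry no net charge, so matching counts did not keep these two compounds close; what differs in the count is the seven heavy atoms against one. Nothing available here gives a measured reason for the size of this step.

The compounds shown leave open whether a simple amine or a methoxy group on this carbon would stay close to compound 1. They also leave open whether an acetylamino group, which lacks the fluorine atoms, would give a step of similar size.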